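The source may report more compounds than this note shows. Statements on the series, on what has been measured and on what is new or still open speak of the compounds shown alone.

Measured compounds:
compound 1 `Cc1cc(C(=O)N2CCCCc3ccccc32)ccc1CNC(=O)Nc1ccccc1` gives 130 nM
compound 2 `Cc1cc(C(=O)N2CCCCc3ccccc32)ccc1CNC(=O)NCC(=O)OC(C)C` gives 140 nM

Both compounds share the same core and differ only at the far end of the chain on the amide-type nitrogen. In a functional assay on HEK293 cells for agonist activity at Vasopressin V2 receptor (Homo sapiens), read by a luciferase reporter and cAMP accumulation (a lower number here means that less compound is needed, a higher number that more compound is needed for the effect), compound 1 gives 130 nM, and compound 2 gives 140 nM. Going by the values given here, the single step between them, a 1.1-fold higher number from compound 1 to compound 2 (0.03 log units; within the scatter), shows that exchanging phenyl for (isopropoxycarbonyl)methyl at this position leaves the read-out essentially unchanged. Compound 2 therefore stands at the higher of the two numbers, but its gap to compound 1 lies within the scatter, so no order between them can be drawn.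

Compound 3 `Cc1cc(C(=O)N2CCCCc3ccccc32)ccc1CNC(=O)NCC(N)=O` is not yet measured. Its difference from compound 2 is amino in place of isopropoxy on a carbonyl carbon: the ester end of the chain becomes a carbamoyl group. Among the compounds with values here, the only step that bears on this end of the molecule is a 1.1-fold higher number from compound 1 to compound 2 (0.03 log units; within the scatter), which was flat even though the groups exchanged there differed far more than isopropoxy and amino do. On that basis, no step beyond the scatter is expected for a 1.1-fold higher number from compound 2 to compound 3 (0.03 log units; within the scatter), with the value for compound 3 estimated at 150 nM, ranging from 60 nM to 400 nM.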

Compound 3, half-maximal effective concentration: 210 nM
Compound 3: the middle estimate sits 1.4-fold (0.15 log units) below what was measured, within the range that was stated.
By their numbers in this assay, from the lowest: compounds 1, 2 and 3 (each within the scatter of the next).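

In this assay, amino in place of isopropoxy on the carbonyl carbon gives a 1.5-fold higher number from compound 2 to compound 3 (0.18 log units; within the scatter), so this step stays within the scatter even though the two groups differ in their counts of heavy atoms and hydrogen-bond donors. Comparing carbamoylmethyl directly with phenyl on the amide-type nitrogen gives a 1.6-fold higher number from compound 1 to compound 3 (0.21 log units; within the scatter), also within the scatter, so the read-out does not separate phenyl, (isopropoxycarbonyl)methyl and carbamoylmethyl at this position, and the aryl and the two carbonyl-bearing ends cannot be ranked. No measurement at hand accounts for this lack of separation.

As far as these compounds go, it remains open whether a carboxylic acid or a primary amine at the end of the chain, or a longer chain between the amide-type nitrogen and the carbonyl, would give a step beyond the scatter. From the compounds shown here alone, all three compounds carry the same core, so it is also open whether the same exchanges would stay within the scatter on a core bearing a different group in place of the methyl.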